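This account rests on a few compounds, and the source may have more. Where it says the series, first, only, none or still open, it means among the compounds named here.

Series values in a functional assay on MCF7 cells (Homo sapiens) for cytotoxicity, read by MTT assay, with a stated time of 96 h; a lower number here means a stronger inhibitor, a higher number a weaker inhibitor:
- compound 1 `COc1cc(C(=O)c2cn(-c3cccc(N)c3)cc2-c2ccc([N+](=O)[O-])cc2)cc(OC)c1OC`: 110 nM
- compound 2 `COc1cc(C(=O)c2cn(-c3ccc(F)cc3)cc2-c2ccc([N+](=O)[O-])cc2)cc(OC)c1OC`: 240 nM
- compound 3 `COc1cc(C(=O)c2cn(-c3ccc(F)cc3)cc2-c2ccc(N)cc2)cc(OC)c1OC`: 12 nM

Of the three, compound 2 has the highest number, 240 nM. Compound 4 `COc1cc(C(=O)c2cn(-c3ccc(N)cc3)cc2-c2ccc([N+](=O)[O-])cc2)cc(OC)c1OC` has amino in place of fluoro on an aromatic carbon. The closest measured change is a 2.2-fold higher number from compound 1 to compound 2 (0.34 log units; beyond the scatter), a modest step that swaps 3-aminophenyl for 4-fluorophenyl on an aromatic nitrogen. Read in reverse, it suggests a lower number with amino present. The large step of a 20-fold lower number from compound 2 to compound 3 (1.30 log units; beyond the scatter) replaces nitro at a different place, so it bears only weakly. A modest drop is therefore expected in this assay: the expected step is a 2.4-fold lower number from compound 2 to compound 4 (0.38 log units; beyond the scatter). The estimate for compound 4 is 100 nM, with an expected range of 30 nM to 300 nM.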

Compound 4, half-maximal inhibitory concentration: 260 nM
Beside the measured number, compound 4's estimate is 2.6-fold (0.41 log units) below it, and the stated range covers the measured number.
By their numbers in this assay, from the lowest: compound 3; then compound 1; then compounds 2 and 4 (each within the scatter of the next).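

With nitro kept, amino and fluoro at the end of the group on the aromatic nitrogen read alike in this assay, with a 1.1-fold higher number from compound 2 to compound 4 (0.03 log units; within the scatter) as the step from 4-fluorophenyl to 4-aminophenyl. The amino location does register, with a 2.4-fold higher number from compound 1 to compound 4 (0.37 log units; beyond the scatter) as a modest step for 4-aminophenyl in place of 3-aminophenyl. No measured evidence accounts for either step.

Still open, as far as these compounds go, is whether methoxy or hydroxyl at this place would also read alike. Also open, from the compounds shown here alone, is whether the match between amino and fluoro holds with amino in place of nitro, as in compound 3.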